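Sulfonyl series notes: compound 3 to compound 4

The source may report more compounds than this note shows. Statements on the series, on what has been measured and on what is new or still open speak of the compounds shown alone.

- compound 1 `C=CCCCCCCCS(=O)(=O)/C=C/c1ccc(O)c(O)c1`: 6900 nM
- compound 2 `O=S(=O)(/C=C/c1ccc(O)c(O)c1)CC1CCC1`: 8800 nM
- compound 3 `O=S(=O)(/C=C/c1ccc(O)c(O)c1)CCCCCCCCCO`: 7500 nM

In a functional assay, read by fluorescence and spectrophotometry, with a stated time of 1 h (on this read-out lower numbers stand for an effect already at smaller amounts and higher numbers for an effect only at larger amounts of compound), compound 3 gives 7500 nM. This value lies within the scatter of both other measured values, so the three compounds cannot be ranked on these numbers.

The next structure is compound 4 `O=S(=O)(/C=C/c1ccc(O)c(O)c1)CCCC1CCCC1`, which differs from compound 3 as follows: cyclopentyl in place of 6-hydroxyhexyl on a saturated chain carbon, three bonds along the chain from a sulfonyl sulfur. Cyclopentyl comes in place of 6-hydroxyhexyl on a saturated chain carbon, three bonds along the chain from a sulfonyl sulfur.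

Going by the values given here, one measured step bears on this change: a 1.1-fold higher number from compound 1 to compound 3 (0.04 log units; within the scatter). That step places 2-hydroxyethyl in place of vinyl on a saturated chain carbon, seven bonds along the chain from a sulfonyl sulfur, and it stays within the scatter. Among the compounds with values here, it is only a partial guide, since no measured step exchanges 6-hydroxyhexyl or introduces cyclopentyl. Compound 2, at 8800 nM, also stays within the scatter of compound 3, despite its different group on the sulfonyl side.

No step beyond the scatter is therefore expected in this assay, and no direction can be favoured. The estimated change is a 1.1-fold higher number from compound 3 to compound 4 (0.03 log units; within the scatter). For compound 4 the expected value is 8000 nM, with an estimated range of 4000 nM to 16000 nM.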

Compound 4, half-maximal effective concentration: 6300 nM
Compound 4: the middle estimate sits 1.3-fold (0.10 log units) above what was measured; measured number inside the range.
By their numbers in this assay, from the lowest: compounds 4, 1, 3 and 2 (each within the scatter of the next).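

In this assay, going by these compounds alone, cyclopentyl in place of 6-hydroxyhexyl, on a saturated chain carbon three bonds along the chain from a sulfonyl sulfur, gives a 1.2-fold lower number from compound 3 to compound 4 (0.08 log units; within the scatter) and so stays within the scatter; this is the first measured exchange at this position of an open chain for a five-membered ring of carbon only, and the hydroxyl-bearing chain can go without a step beyond the scatter. Cyclopentyl in place of hex-5-en-1-yl at the same position gives a 1.1-fold lower number from compound 1 to compound 4 (0.04 log units; within the scatter) and, with 2-cyclopentylethyl in place of cyclobutyl on a saturated chain carbon bound to a sulfonyl sulfur, the numbers give a 1.4-fold lower number from compound 2 to compound 4 (0.15 log units; within the scatter) as well, so neither comparison separates the compounds and the four cannot be ranked on these numbers. Nothing available bears on why these exchanges leave the number within the scatter.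

Still open, on these data alone, is whether an amine or a carboxylic acid on this chain would give a step beyond the scatter. Also open, as far as these compounds go, is whether a phenyl ring at this position, or a chain longer than 6-hydroxyhexyl, would do so.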